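Fluorine on the pyridine ring in two sulfone cores

The compounds below may be only part of what the source reports. "The series", "measured", "known", "first", "only" and "open" are said of these compounds alone.

Measured so far:
compound 1 `O=S(=O)(/C=C/c1ccccn1)c1ccccc1F` gives 1050 nM
compound 2 `O=S(=O)(/C=C/c1ncccc1F)c1ccccc1F` gives 176 nM
compound 3 `O=S(=O)(/C=C/c1ccccn1)c1cccc(F)c1` gives 1680 nM

All three were tested in an assay on U2OS cells for activation of nuclear factor erythroid 2-related factor 2 (Homo sapiens), read by beta-arrestin recruitment, with a stated time of 6 h; on this read-out higher numbers stand for an effect only at larger amounts of compound and lower numbers for an effect already at smaller amounts. Compound 1 and compound 3 share the same atoms joined differently; how the two cores differ is not broken down here, and their values lie within the scatter of each other. Compound 2 carries the change fluoro in place of hydrogen on an aromatic carbon on the core of compound 1, and that step was a 6.0-fold lower number from compound 1 to compound 2 (0.78 log units; beyond the scatter). Compound 4 `O=S(=O)(/C=C/c1ncccc1F)c1cccc(F)c1` carries the same change, (fluoro in place of hydrogen on an aromatic carbon), on the core of compound 3. Because the earlier step of a 6.0-fold lower number from compound 1 to compound 2 (0.78 log units; beyond the scatter) was clearly beyond the scatter, a step of similar size is expected here, a 5.3-fold lower number from compound 3 to compound 4 (0.72 log units; beyond the scatter), giving for compound 4 an estimated 320 nM in this assay, most likely between 120 nM and 850 nM.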

Compound 4, half-maximal effective concentration: 474 nM
Beside the measured number, compound 4's estimate is 1.5-fold (0.17 log units) below it, and the stated range covers the measured number.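

In this assay fluoro in place of hydrogen on an aromatic carbon lowers the number on the second core as well (a 3.5-fold lower number from compound 3 to compound 4 (0.55 log units; beyond the scatter)). Set beside the earlier step, the change carries over from one core to the other with no difference that can be told apart: the same change on two cores in this assay, a 6.0-fold lower number (0.78 log units; beyond the scatter) from compound 1 to compound 2 and a 3.5-fold lower number (0.55 log units; beyond the scatter) from compound 3 to compound 4, 1.7-fold (0.23 log units) apart, within the scatter of two such steps. Among these compounds, this rests on only two cores and one read-out, so it does not show that the change would behave the same way on other cores, nor why the number falls.

The compounds shown leave open whether another group in the same place, such as chloro, methoxy or an amine, would give a step of similar size. They also leave open what fluoro would do on a different carbon of the ring with the nitrogen.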